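Nitro-benzyl amines on a shared core: bromo to trifluoromethyl

This account rests on a few compounds, and the source may have more. Where it says the series, first, only, none or still open, it means among the compounds named here.

Compound 1 `Oc1ccc(CNc2cc(C(F)(F)F)cc3[nH]ncc23)cc1` gives 36700 nM in an assay for inhibition of Indoleamine 2,3-dioxygenase 1 (Homo sapiens), with stated times of 10 min and 60 min; on this read-out higher numbers stand for weaker inhibition and lower numbers for stronger inhibition.
Compound 2 `O=[N+]([O-])c1ccc(CNc2cc(Br)cc3[nH]ncc23)cc1` gives 6970 nM in this assay.

Of the compounds shown here, two have been measured so far. For the measured compounds named here, compound 2 stands lowest of the two numbers; the only other value, that of compound 1, lies well beyond the scatter above it. Since the two differ in more than one place, the gap between them cannot be laid to any single change.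

Compound 3 `O=[N+]([O-])c1ccc(CNc2cc(C(F)(F)F)cc3[nH]ncc23)cc1` has not yet been measured. It keeps the nitro-bearing benzyl group of compound 2 and differs from it only on the shared core: trifluoromethyl in place of bromo on an aromatic carbon. Going by the values given here, no pair of measured compounds shows this exchange on its own, so no measured step speaks to its size or direction. With nothing to support a shift either way, compound 3 is expected to stay close to compound 2, within the scatter, and the estimated step of a 1.3-fold higher number from compound 2 to compound 3 (0.11 log units; within the scatter) is accordingly small. On that basis compound 3 is estimated at 9000 nM in this assay, with a range from 3000 nM to 30000 nM.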

Compound 3, half-maximal inhibitory concentration: 61000 nM
Compound 3: middle estimate off by 6.8-fold (0.83 log units), on the low side; the measured number lies above the stated range.
By their numbers in this assay, from the lowest: compound 2; then compounds 1 and 3 (each within the scatter of the next).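

Read directly in this assay with the nitro group held constant, trifluoromethyl in place of bromo on this aromatic carbon of the shared core gives an 8.8-fold higher number from compound 2 to compound 3 (0.94 log units; beyond the scatter) and lies beyond the scatter, so the group at this place clearly matters in this pair. With trifluoromethyl held constant, nitro in place of hydroxy on an aromatic carbon of the benzyl group gives a 1.7-fold higher number from compound 1 to compound 3 (0.22 log units; within the scatter) and stays within the scatter. Nothing available explains the size of either step.

Whether the exchange of bromo for trifluoromethyl would give a step of similar size with hydroxy in place of nitro remains open, since the compounds shown contain only one pair for that exchange. Also open, going by these compounds, is how this place on the shared core would respond to chloro, methyl, a nitrile or an amine, and how the benzyl group would respond to a carboxylic acid or a methoxy group.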